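The compounds below may be only part of what the source reports. "The series", "measured", "known", "first", "only" and "open" are said of these compounds alone.

Working notes on the series, read in a functional assay on CNE-2 cells (Homo sapiens) for antiproliferative activity, read by sulforhodamine B assay, with a stated time of 48 h; a lower number here means a stronger inhibitor, a higher number a weaker inhibitor. Compound 1 `COc1cccc(/C=C/C(=O)C(=Cc2ccc(F)cc2)C(=O)/C=C/c2cccc(OC)c2OC)c1OC` gives 610 nM and compound 2 `COc1cccc(/C=C/C(=O)C(=Cc2cc(OC)c(OC)c(OC)c2)C(=O)/C=C/c2cccc(OC)c2OC)c1OC` gives 400 nM. These two numbers lie within the scatter of each other, so compound 2 cannot be separated from compound 1 on the data so far.

The change under review leads to compound 3 `COc1cc(OC)c(C=C(C(=O)/C=C/c2cccc(OC)c2OC)C(=O)/C=C/c2cccc(OC)c2OC)c(OC)c1`, which has 2,4,6-trimethoxyphenyl in place of 3,4,5-trimethoxyphenyl on a double-bonded chain carbon bound to a double-bonded chain carbon.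

For the measured compounds named here, only one measured step bears on this place: a 1.5-fold lower number from compound 1 to compound 2 (0.18 log units; within the scatter), with 3,4,5-trimethoxyphenyl in place of 4-fluorophenyl, and it stays within the scatter. Going by the values given here, no measured compound carries the 2,4,6-trimethoxyphenyl group, so the evidence is thin and gives no firm direction. With that single step as the guide, no shift beyond the scatter is expected in this assay. The expected change is a 1.3-fold higher number from compound 2 to compound 3 (0.10 log units; within the scatter). For compound 3 the estimated value is 500 nM, with an expected range from 150 nM to 1600 nM.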

Compound 3, half-maximal inhibitory concentration: 630 nM
Estimate against measurement, compound 3: 1.3-fold (0.10 log units) below, within the range that was stated.
By their numbers in this assay, from the lowest: compounds 2, 1 and 3 (each within the scatter of the next).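

In this assay, rearranging the methoxy groups from 3,4,5-trimethoxyphenyl to 2,4,6-trimethoxyphenyl gives a 1.6-fold higher number from compound 2 to compound 3 (0.20 log units; within the scatter) and stays small, while 2,4,6-trimethoxyphenyl in place of 4-fluorophenyl gives a 1.0-fold higher number from compound 1 to compound 3 (0.01 log units; within the scatter) and is equally unresolved. For the compounds shown here, the position on a double-bonded chain carbon bound to a double-bonded chain carbon now holds three different aromatic groups, including two isomers with the same atoms joined differently, and no pair among them separates beyond the scatter, so neither the arrangement of the methoxy groups nor the exchange of fluorine for methoxy groups has a readable effect on these numbers. Nothing measured here speaks to the reason the three compounds read alike.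

Going by these compounds, all three compounds carry a substituted phenyl ring at this place, so it remains open whether a group of another kind there, such as an amine, a carboxylic acid or a longer alkyl chain, would give a step beyond the scatter. Also open, on these data alone, is whether this flat reading would persist with a change elsewhere on the shared core.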